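The source may hold more compounds than are shown below. What is called first, only, known or untested is meant among the compounds shown, and "the series" means these compounds.

Compound 1 `C=C(CC)C(=O)c1ccc(OCC(=O)Nc2ccc(/C=C/C(=O)NO)cc2)c(Cl)c1Cl`: 2600 nM
Compound 2 `C=C(CC)C(=O)c1ccc(OCC(=O)Nc2ccc(/C=C/C(=O)OCC)cc2)c(Cl)c1Cl`: 1700 nM
Compound 3 `C=C(CC)C(=O)c1ccc(OCC(=O)Nc2ccc3c(c2)C(O)N=NC3O)c(Cl)c1Cl`: 8500 nM

In a functional assay on CLL cells (Homo sapiens) for cytotoxicity, read by MTT assay, with a stated time of 48 h (on this read-out lower numbers stand for an effect already at smaller amounts and higher numbers for an effect only at larger amounts of compound), compound 2 shares the low end of these numbers with compound 1, while compound 3 stands clearly higher. Still unmeasured, compound 4 `C=C(CC)C(=O)c1ccc(OCC(=O)Nc2ccc(C(=O)OC)cc2)c(Cl)c1Cl` differs from compound 2 as follows: methoxycarbonyl in place of 2-(ethoxycarbonyl)ethenyl on an aromatic carbon. In words, this is methoxycarbonyl in place of 2-(ethoxycarbonyl)ethenyl on an aromatic carbon. Among the compounds with values here, only one measured step bears on this, and only loosely: a 1.5-fold lower number from compound 1 to compound 2 (0.18 log units; within the scatter), a change inside the group that leaves here. That step kept the ethenyl part, so no measurement covers its loss. No shift beyond the scatter is therefore expected in this assay, in either direction, and the expected step is a 1.5-fold higher number from compound 2 to compound 4 (0.17 log units; within the scatter). The estimate for compound 4 is 2500 nM, with an expected range of 900 nM to 7000 nM.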

Compound 4, half-maximal effective concentration: 4100 nM
The estimate for compound 4 lay 1.6-fold (0.21 log units) below the measured number, within the range that was stated.
By their numbers in this assay, from the lowest: compounds 2, 1 and 4 (each within the scatter of the next, the first and the last beyond it); then compound 3.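

In this assay, methoxycarbonyl in place of 2-(ethoxycarbonyl)ethenyl gives a 2.4-fold higher number from compound 2 to compound 4 (0.38 log units; beyond the scatter) as a modest change, so this position does respond when the ethenyl part goes as well as the end of the group. The same methoxycarbonyl in place of 2-(hydroxycarbamoyl)ethenyl gives a 1.6-fold higher number from compound 1 to compound 4 (0.20 log units; within the scatter) and so stays inside the usual variation, which means the outcome depends on which group leaves. Nothing available here gives a reason for these steps.

Open, going by these compounds, is how a carboxylic acid or an amine on this aromatic carbon would compare, and whether a longer chain ending in an ester would differ from these groups.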